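The source may hold more compounds than are shown below. What is called first, only, known or untested is meant among the compounds shown, and "the series" means these compounds.

Measured in a functional assay on NCI-H460 cells (Homo sapiens) for inhibition, read by sulforhodamine B assay, with a stated time of 48 h; a lower number here means a stronger inhibitor of growth, a higher number a weaker inhibitor of growth:
- Compound 1 `CC(C)(C)NCc1c(C(=O)O)nn(-c2ccc(Cl)cc2)c1-c1ccc(Cl)cc1`: > 599000 nM, a limit
- Compound 2 `CC(C)(C)NCc1c(C(=O)O)nn(-c2ccc(Cl)cc2)c1-c1ccccc1`: > 652000 nM, a limit

From the compounds shown here alone, compound 2 has only a limit, > 652000 nM, so its true place is unknown. Compound 3 `CC(C)(C)NCc1c(C(=O)O)nn(-c2ccc(Cl)cc2)c1-c1ccc([N+](=O)[O-])cc1` differs from compound 2 by one change: nitro in place of hydrogen on an aromatic carbon. For the measured compounds named here, the only measured step is a step that the two limits leave unreadable from compound 1 to compound 2, so it offers no size to carry over, and no measured compound carries a nitro group. With no sign of a gain, the expected step in this assay is small and favours neither direction: an at least 1.1-fold lower number from compound 2 to compound 3 (0.05 log units; that floor lies within the scatter). Compound 3 is estimated at 580000 nM, with an expected range of 200000 nM to 800000 nM.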

Compound 3, concentration for 50% growth inhibition: 141000 nM
Compound 3: the middle estimate sits 4.1-fold (0.61 log units) above what was measured; the measured number lies below the stated range.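

In this assay, placing nitro on the aromatic carbon para to a large group gives an at least 4.6-fold lower number from compound 2 to compound 3 (0.66 log units; beyond the scatter), and the same group in place of chloro gives an at least 4.2-fold lower number from compound 1 to compound 3 (0.62 log units; beyond the scatter). This position can therefore shift growth inhibition to a measurable number, which the chloro and hydrogen compounds did not show, and the step between those two cannot be read. Nothing shown here explains the gain.

From the compounds shown here alone, the full size of both steps stays open. So does whether a nitrile or a methoxy group at this position would give a similar gain.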